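This account rests on a few compounds, and the source may have more. Where it says the series, first, only, none or still open, it means among the compounds named here.

For the measured compounds named here, in a functional assay on SK-MEL-2 cells (Homo sapiens) for antiproliferative activity (on this read-out lower numbers stand for stronger inhibition of growth and higher numbers for weaker inhibition of growth), compound 2 (`c1ccc(-c2cc(-c3cccs3)cc(-c3ccncc3)n2)nc1`) gives 35.2 ug/mL, the higher of the two numbers so far, while compound 1 (`c1ccc(-c2cc(-c3cccs3)cc(-c3ccccn3)n2)nc1`) gives 1.8 ug/mL. Compound 3 (`c1ccc(-c2cc(-c3cccs3)cc(-c3cccnc3)n2)nc1`) carries pyridin-3-yl in place of pyridin-4-yl on an aromatic carbon. Going by the values given here, one measured step bears on this change, the exchange of pyridin-2-yl for pyridin-4-yl at the same place, which gave a 20-fold higher number from compound 1 to compound 2 (1.29 log units; beyond the scatter), a large step. Going by compound 1 at 1.8 ug/mL and compound 2 at 35.2 ug/mL, a moderate move towards a lower number is expected, smaller than that step. The expected change is a 3.9-fold lower number from compound 2 to compound 3 (0.59 log units; beyond the scatter). For compound 3 the estimated value is 9 ug/mL, with an expected range of 2.5 ug/mL to 32 ug/mL.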

Compound 3, concentration for 50% growth inhibition: 77.7 ug/mL
For compound 3 the middle estimate is 8.6-fold (0.94 log units) below the measured one; the whole stated range lies below it.
By their numbers in this assay, from the lowest: compound 1; then compound 2; then compound 3.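

In this assay the pyridin-3-yl group does not land between the other two pyridines: there is a 2.2-fold higher number from compound 2 to compound 3 (0.34 log units; beyond the scatter), and a 43-fold higher number from compound 1 to compound 3 (1.64 log units; beyond the scatter). Among these three compounds, the low number at this position therefore belongs to the pyridin-2-yl group of compound 1 alone, and both other attachments give much weaker inhibition of growth. Nothing measured here explains this order. Still open, going by these compounds, is how a plain phenyl group, or a pyridin-2-yl group carrying an amine, would behave at this place.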